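A few compounds are considered here, and "the series" means these few. Any claim that something is new, unique, unknown or untested is made for them only; others in the source may bear on it.

The series is built on a shared core carrying a hexafluoro-2-hydroxypropan-2-yl group and a phenol, to which an ether-linked amide side chain is attached. Compound 1 `CCCNC(=O)COc1ccc2cc(C(O)(C(F)(F)F)C(F)(F)F)c(O)cc2c1` is the smallest member of that set. In an assay on isolated protein for inhibition of tyrosine-protein phosphatase non-receptor type 13 (Homo sapiens), read by spectrophotometry (a higher number here means a weaker inhibitor, a lower number a stronger inhibitor), compound 1 gives > 20000 nM, which is a limit of the measurement rather than a number, so compound 1 sits at the limit of > 20000 nM in this assay, at which 1 of the 3 values shown sits. Compound 2 `Oc1cc(-c2ccccc2)ccc1C(O)(C(F)(F)F)C(F)(F)F` lacks the side chain altogether, and in this assay compound 2 reaches only > 500000 nM, again a limit, (the limit of > 500000 nM in this assay, at which 1 of the 3 values shown sits). Among the compounds with values here, the one compound with a real number is compound 3 `CC(C)c1ccc(NC(=O)COc2ccc3cc(C(O)(C(F)(F)F)C(F)(F)F)c(O)cc3c2)cc1`, which in this assay gives 6500 nM. Within the data shown here, the step of an at least 3.0-fold lower number from compound 1 to compound 3 (0.48 log units; beyond the scatter) is the only measured change of the amide substituent, and it shows that a large aryl group on that nitrogen brings the value into the measurable range.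

Compound 4 `O=C(COc1ccc2cc(C(O)(C(F)(F)F)C(F)(F)F)c(O)cc2c1)NC1CC1` changes the amide substituent in a different way: cyclopropyl in place of propyl on an amide-type nitrogen. This change keeps the substituent small, so the step from compound 1 to compound 3 gives no direct guide, and compound 2 shows what happens when the chain is absent. Compound 4 is therefore expected to stay close to compound 1, with an estimated step that the limit leaves unreadable from compound 1 to compound 4. The estimate for compound 4 is 30000 nM, within a range of 10000 nM to 100000 nM.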

Compound 4, half-maximal inhibitory concentration: > 20000 nM
Compound 4: a limit, no number; the forecaster's own chance of this, stated with the estimate: 70%; the middle value lies beyond the limit too.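

In this assay compound 4 gives > 20000 nM, which is a limit of the measurement and not a number, and compound 1 sits at the same limit: the limit of > 20000 nM in this assay, at which 2 of the 4 values shown sit. The step between these two compounds cannot be read, so the data show only that neither cyclopropyl nor propyl on the amide-type nitrogen gives a measurable value in this assay. Cyclopropyl in place of 4-isopropylphenyl gives an at least 3.0-fold higher number from compound 3 to compound 4 (0.48 log units; beyond the scatter), which adds a second comparison to the one between propyl and 4-isopropylphenyl and shows that a three-membered non-aromatic ring at this position does not match the aromatic substituent of compound 3.

Still open is which part of the 4-isopropylphenyl group matters, since an unsubstituted phenyl, a benzyl group or a longer chain such as hexyl on the same nitrogen does not appear among these compounds. As far as these compounds go, it is also open how the value would respond to a carboxylic acid or an amine carried on that substituent, and how far below the limit of compound 1 or compound 4 any such change could reach.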